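Removing the Amide Methyl: Clearance Outlook for Compound 3

This account rests on a few compounds, and the source may have more. Where it says the series, first, only, none or still open, it means among the compounds named here.

Compound 1, `CC(c1cc2cccnc2cc1F)n1cnc2ncc(-c3cnn(C)c3)nc21`, gives 18 uL/min in an ADME assay on microsomes from liver (Rattus norvegicus) for metabolic stability, read by LC-MS, using NADPH, with stated times of 5 min and 30 min, tested at 1 uM; a lower number here means slower removal, a higher number faster removal of the compound. Compound 2, `CNC(=O)c1ccc(-c2cnc3ncn(C(C)c4cc5cccnc5cc4F)c3n2)cc1F`, gives 85 uL/min in this assay.

Going by the values given here, compound 2 stands highest of the two numbers measured so far, and the only measured step is a 4.7-fold higher number from compound 1 to compound 2 (0.67 log units; beyond the scatter), which exchanged 1-methyl-1H-pyrazol-4-yl for 3-fluoro-4-(methylcarbamoyl)phenyl on an aromatic carbon. The next compound, compound 3, `CC(c1cc2cccnc2cc1F)n1cnc2ncc(-c3ccc(C(N)=O)c(F)c3)nc21`, has not yet been tested in this assay. It differs from compound 2 by hydrogen in place of methyl on an amide-type nitrogen. Among the compounds with values here, the single measured step replaced an entire ring substituent, so it bears only loosely on a change confined to the amide-type nitrogen; no measured pair isolates this methyl alone. With nothing closer to lean on, the expectation is a step that stays within the usual scatter, leaning if anything toward a lower number. Compound 3 is expected to give 60 uL/min in this assay, with a range from 30 uL/min to 120 uL/min. This estimate amounts to a step of a 1.4-fold lower number from compound 2 to compound 3 (0.15 log units; within the scatter), expected to remain within the scatter.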

Compound 3, intrinsic clearance in a liver preparation (reported as CLH), per the amount of preparation that the assay uses: 85 uL/min
Compound 3: middle estimate off by 1.4-fold (0.15 log units), on the low side; measured number inside the range.
By their numbers in this assay, from the lowest: compound 1; then compounds 2 and 3 (each within the scatter of the next).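

In this assay, going by these compounds alone, the step from methyl to hydrogen on the amide-type nitrogen is no change at the digits printed from compound 2 to compound 3 (within the scatter), and this pair is the first to isolate that single methyl: at this place, the two compounds cannot be told apart in this assay. The other new step, a 4.7-fold higher number from compound 1 to compound 3 (0.67 log units; beyond the scatter), has the same size as a 4.7-fold higher number from compound 1 to compound 2 (0.67 log units; beyond the scatter), so the rise from the compound carrying 1-methyl-1H-pyrazol-4-yl appears with 4-carbamoyl-3-fluorophenyl as well as with 3-fluoro-4-(methylcarbamoyl)phenyl on the aromatic carbon. No measurement at hand offers an explanation for either result.

The compounds shown leave open how the number would respond to an ethyl group or a longer chain on the amide-type nitrogen, or to a carboxylic acid or a nitrile in place of the whole carbamoyl group. They also leave open which part of the 4-carbamoyl-3-fluorophenyl group carries the rise, as a phenyl ring with no fluorine or one with no carbamoyl group would be needed to separate the two.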